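Removing the prenyl chain from compound 3

The source may hold more compounds than are shown below. What is called first, only, known or untested is meant among the compounds shown, and "the series" means these compounds.

In a functional assay on HeLa cells (Homo sapiens) for inhibition, read by MTT assay, with a stated time of 72 h (on this read-out higher numbers stand for weaker inhibition and lower numbers for stronger inhibition), compound 1 `COc1ccc(/C=C/C(=O)c2c(OC)cc(O)c(CC=C(C)C)c2O)cc1` reads > 50000 nM, which is a limit of the assay and not a number. Compound 2 `COc1cc(O)c(CC=C(C)C)c(O)c1C(=O)/C=C/c1ccc([N+](=O)[O-])cc1` gives 29700 nM, and compound 3 `COc1cc(O)c(CC=C(C)C)c(O)c1C(=O)/C=C/c1ccc(C(F)(F)F)cc1` gives 6800 nM, the lowest number in the series. The steps leading to compound 3 are an at least 7.3-fold lower number from compound 1 to compound 3 (0.86 log units; beyond the scatter) and a 4.4-fold lower number from compound 2 to compound 3 (0.64 log units; beyond the scatter), while an at least 1.6-fold lower number from compound 1 to compound 2 (0.22 log units; that floor lies within the scatter) has a floor within the scatter.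

Compound 4 `COc1cc(O)cc(O)c1C(=O)/C=C/c1ccc(C(F)(F)F)cc1` carries hydrogen in place of 3-methylbut-2-en-1-yl on an aromatic carbon, (hydrogen in place of 3-methylbut-2-en-1-yl on an aromatic carbon). All three measured steps exchange methoxy, nitro and trifluoromethyl groups and retain the 3-methylbut-2-en-1-yl group, so none tests this change directly. They serve only as a rough guide to step size in this assay. With compound 3 at 6800 nM, the low end of the series, a higher number is the more likely direction, though this remains uncertain. The expected step is a 2.9-fold higher number from compound 3 to compound 4 (0.47 log units; beyond the scatter). For compound 4 the estimated value is 20000 nM, with an expected range of 7000 nM to 50000 nM.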

Compound 4, half-maximal inhibitory concentration: 9500 nM
Compound 4: the middle estimate sits 2.1-fold (0.32 log units) above what was measured; low and high end bracket the measured number.
By their numbers in this assay, from the lowest: compounds 3 and 4 (each within the scatter of the next); then compound 2. At a limit, above all of these: compound 1.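

In this assay, for the compounds shown here, the only step at this position, on the aromatic carbon ortho to two hydroxy groups, removes the 3-methylbut-2-en-1-yl group and gives a 1.4-fold higher number from compound 3 to compound 4 (0.15 log units; within the scatter). Going by these compounds alone, with trifluoromethyl in place, the read-out therefore does not depend on the 3-methylbut-2-en-1-yl group, a point the earlier steps could not address since all of them retain it. No available measurement bears on why this step is so small.

From the compounds shown here alone, whether the same holds with methoxy or nitro in place of trifluoromethyl remains open, since this one pair cannot show it. Also open, going by these compounds, is what this position would give with a longer chain such as geranyl, a shorter one such as methyl, or a carboxylic acid or an amine.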